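Replacing the furan with cinnamoyl on a weak cytotoxic series

This account rests on a few compounds, and the source may have more. Where it says the series, first, only, none or still open, it means among the compounds named here.

The three measured compounds share a threonine-derived core carrying an alkyl amide and a furan-2-yl carbonyl on the amine. Compound 1 `CCCCCCCCNC(=O)[C@@H](NC(=O)c1ccco1)[C@@H](C)O` gives 64500 nM in a functional assay on A-431 cells (Homo sapiens) for cytotoxicity, read by MTT assay, with a stated time of 48 h; a higher number here means a weaker inhibitor, a lower number a stronger inhibitor. Compound 2 `CCCCCCCCCCCCNC(=O)[C@@H](NC(=O)c1ccco1)[C@@H](C)O` gives 92400 nM in this assay, and compound 3 `CCCCCCCCCCCCCCNC(=O)[C@@H](NC(=O)c1ccco1)[C@@H](C)O` gives 190000 nM. The steps along the chain are a 1.4-fold higher number from compound 1 to compound 2 (0.16 log units; within the scatter), a 2.9-fold higher number from compound 1 to compound 3 (0.47 log units; beyond the scatter) and a 2.1-fold higher number from compound 2 to compound 3 (0.31 log units; beyond the scatter), so compound 3 stands highest of the three numbers, with compound 2 nearest and compound 1 furthest.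

Compound 4 `CCCCCCCCCCCCCCNC(=O)[C@@H](NC(=O)/C=C/c1ccccc1)[C@@H](C)O` differs from compound 3 at the amide-bound carbonyl: 2-phenylethenyl in place of furan-2-yl on a carbonyl carbon. Among the measured compounds shown here, none of the measured steps touches this carbonyl group; all of them vary the alkyl chain, so no measured step bears directly on the change. With nothing to anchor a direction, the expected step of no change at the digits printed from compound 3 to compound 4 (within the scatter) from compound 3 to compound 4 is none beyond the scatter. Compound 4 is therefore estimated at 190000 nM in this assay, with a range from 60000 nM to 600000 nM.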

Compound 4, half-maximal inhibitory concentration: 64900 nM
The estimate for compound 4 lay 2.9-fold (0.47 log units) above the measured number, and the stated range covers the measured number.
By their numbers in this assay, from the lowest: compounds 1, 4 and 2 (each within the scatter of the next); then compound 3.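

In this assay, among the compounds shown here, the earlier steps varied only the alkyl chain and each raised the number, so they said nothing about the group on the carbonyl carbon. This position also matters: 2-phenylethenyl in place of furan-2-yl gives a 2.9-fold lower number from compound 3 to compound 4 (0.47 log units; beyond the scatter), the first step shown toward a stronger inhibitor. Nothing available explains this step.

The exchange replaces a five-membered aromatic ring containing oxygen with a benzene ring and adds a double bond outside the ring, so the compounds shown cannot assign the step to either feature; a plain phenyl or a saturated 2-phenylethyl on the same carbonyl carbon would separate them. From the compounds shown here alone, it also remains open whether 2-phenylethenyl would give a step of similar size on an octyl or dodecyl chain.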